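The source may report more compounds than this note shows. Statements on the series, on what has been measured and on what is new or still open speak of the compounds shown alone.

In an ADME assay on microsomes from liver (Mus musculus) for metabolic stability, read by LC-MS, using NADPH, with a stated time of 30 min, tested at 0.1 uM (a lower number here means that less of the compound is left, a higher number that more of the compound is left), the measured compounds read as follows:

compound 1 `O=S(=O)(NCC1COC1)c1cccc(-c2ccc3nccc(-c4ccncc4)c3n2)c1` gives 19% 
compound 2 `CS(=O)(=O)Nc1ccc2nccc(-c3ccncc3)c2n1` gives 95% 
compound 3 `O=S(=O)(NCCN1CCCC1)c1cccc(-c2ccc3nccc(-c4ccnc(C(F)(F)F)c4)c3n2)c1` gives 8% 

Compound 1 stands second highest of these three numbers. Compound 3 lies lower and compound 2 much higher, both gaps beyond the usual scatter. Compound 4 `O=S(=O)(c1cccc(-c2ccc3nccc(-c4ccncc4)c3n2)c1)N1CCC(O)CC1` has not been measured yet. It carries 4-hydroxypiperidin-1-yl in place of ((oxetan-3-yl)methyl)amino on a sulfonyl sulfur. Going by the values given here, no measured pair shows this change alone, so the expectation rests on compound 1 (19%) as its starting point. A small upward step is expected (a number 6 percentage points higher from compound 1 to compound 4 (within the scatter)) and would probably stay within the scatter. The estimate for compound 4 is 25% with an expected range from 8% to 50% in this measurement.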

Compound 4, percent of the compound remaining: 7%
Beside the measured number, compound 4's estimate is 18 percentage points above it, and the stated range ends above it.
By their numbers in this assay, from the lowest: compounds 4 and 3 (each within the scatter of the next); then compound 1; then compound 2.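

Going by these compounds alone, replacing ((oxetan-3-yl)methyl)amino with 4-hydroxypiperidin-1-yl on a sulfonyl sulfur gives the first comparison here of compounds that differ in one place, and in this assay it reads a number 12 percentage points lower from compound 1 to compound 4 (beyond the scatter). The group on this sulfonyl sulfur can therefore change how much compound is left, and this six-membered ring leaves less than the four-membered one. No measurement here explains the step. Still open, from the compounds shown here alone, is how a morpholin-4-yl or dimethylamino group would read at this place, and whether the same change would give a similar step in a compound carrying trifluoromethyl.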